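Swapping the aryl group in a series stuck at the limit

The source may hold more compounds than are shown below. What is called first, only, known or untested is meant among the compounds shown, and "the series" means these compounds.

In a functional assay on MDA-MB-231 cells (Homo sapiens) for cytotoxicity, read by MTT assay, with a stated time of 48 h (on this read-out higher numbers stand for weaker inhibition and lower numbers for stronger inhibition), compound 1 (`COC(=O)c1ccc(-n2cc(CCCOS(=O)(=O)c3ccc(C)cc3)nn2)cc1`) gives > 100000 nM, which is a limit and not a number. Compound 2 (`Cc1ccc(S(=O)(=O)OCCCc2cn(-c3cccc(C#N)c3)nn2)cc1`) gives > 100000 nM, again a limit. Compound 3 (`Cc1ccc(S(=O)(=O)OCCCc2cn(-c3cccc(F)c3)nn2)cc1`) gives > 100000 nM, also a limit, so it has no exact place on the scale. The whole set therefore stands at the limit of > 100000 nM in this assay, at which 3 of the 3 values shown sit.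

The next change leads to compound 4 (`Cc1ccc(-n2cc(CCCOS(=O)(=O)c3ccc(C)cc3)nn2)cc1`) and is described by 4-methylphenyl in place of 3-fluorophenyl on an aromatic nitrogen. In words, it is 4-methylphenyl in place of 3-fluorophenyl on an aromatic nitrogen.

Among the compounds with values here, only one measured step bears on this kind of change, a step that the two limits leave unreadable from compound 2 to compound 3, where fluoro replaces cyano on an aromatic carbon. It offers no size to carry forward. Its value lies in showing that the aryl groups in compound 1, compound 2 and compound 3 all leave the read-out at the limit, and none of the three goes against that pattern.

No shift beyond the usual scatter is expected in this assay, and no direction can be argued, so the expected size is only nominal: a number no higher from compound 3 to compound 4 (the limit leaves the size open). Compound 4 is most likely expected to reach the same limit too. If a number is reported, compound 4 is estimated at 100000 nM, within an expected range of 40000 nM to 200000 nM.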

Compound 4, half-maximal inhibitory concentration: 36600 nM
The estimate for compound 4 lay 2.7-fold (0.44 log units) above the measured number, and the stated range ends above it.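

Within the data shown here, the aryl group on the aromatic nitrogen can move the read-out in this assay, which the earlier compounds, all at one limit, could not show. Replacing the aryl group gives an at least 2.7-fold lower number from compound 3 to compound 4 (0.43 log units; beyond the scatter), and likewise an at least 2.7-fold lower number from compound 2 to compound 4 (0.43 log units; beyond the scatter), with both sizes open at one end; these steps change both the group and its name-given ring number, so they do not separate the two. The cleanest comparison is an at least 2.7-fold lower number from compound 1 to compound 4 (0.43 log units; beyond the scatter), where methyl replaces methoxycarbonyl on an aromatic carbon and the 4-substituted aryl pattern stays, so that pattern alone does not bring a measurable number, and compound 4 remains the only one of these compounds on the scale, with the others at a limit: the limit of > 100000 nM in this assay, at which 3 of the 4 values shown sit.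

The compounds shown leave open whether the methyl group itself matters or whether a 3-methylphenyl group or an unsubstituted phenyl group would serve equally well. They also leave open how an amine or a carboxylic acid on the aryl ring, or a longer chain to the sulfonate ester, would read in this assay.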